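Chloro to methyl on the biaryl of the acid series

The source may hold more compounds than are shown below. What is called first, only, known or untested is meant among the compounds shown, and "the series" means these compounds.

Compound 1 `C[C@H](c1ccc(-c2cc(Cl)ccc2-c2nc(=O)o[nH]2)cc1)N(CC1CC1)c1nc2c(C(=O)O)cccc2o1` carries a carboxylic acid on the shared core and a cyclopropylmethyl group on the nitrogen. In an ADME assay on the whole organism (plasma, Macaca fascicularis) for protein binding, read by LC-MS, using equilibrium dialysis and cassette dosing, with a stated time of 24 h, at a dose of 1 mg/kg by the oral route (on this read-out lower numbers stand for a smaller free fraction and higher numbers for a larger free fraction), compound 1 gives 0.000108. Compound 3 `CCCCN(c1nc2c(NS(C)(=O)=O)cccc2o1)[C@H](C)c1ccc(-c2ccccc2-c2nnn[nH]2)cc1` gives 0.000203 in this assay, a number that sits within the usual scatter of the number for compound 1. Compound 2 `CCCCN(c1nc2ccccc2o1)[C@H](C)c1ccc(-c2ccccc2-c2nnn[nH]2)cc1` gives 0.000713, a number beyond the scatter above compound 1. Compound 4 `Cc1ccc(-c2nc(=O)o[nH]2)c(-c2ccc([C@@H](C)N(CC3CC3)c3nc4c(C(=O)O)cccc4o3)cc2)c1` is not yet measured in this assay.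

The change from compound 1 to compound 4 is methyl in place of chloro on an aromatic carbon. Within the data shown here, the only measured step in the set, a 3.5-fold lower number from compound 2 to compound 3 (0.55 log units; beyond the scatter), concerns a methanesulfonamido group entering on the shared core, a change of a different kind from the one in hand; no measured pair exchanges chloro for methyl, so no step bears directly on it. The groups that leave and enter are each a single heavy atom without ring, donor, acceptor or charge. On this basis the step of a 1.2-fold higher number from compound 1 to compound 4 (0.08 log units; within the scatter) is expected to stay within the scatter, with no direction claimed. Compound 4 is therefore estimated at 0.00013 in this assay, with a range of 0.00006 to 0.0003.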

Compound 4, unbound fraction: 0.00023
Compound 4: the middle estimate sits 1.8-fold (0.25 log units) below what was measured; the measured number falls inside the stated range.
By their numbers in this assay, from the lowest: compounds 1, 3 and 4 (each within the scatter of the next, the first and the last beyond it); then compound 2.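

In this assay, among these compounds, the step of a 2.1-fold higher number from compound 1 to compound 4 (0.33 log units; beyond the scatter) is the first measured exchange at this place, on an aromatic carbon meta to a large group and para to a group of 6 heavy atoms. Among the compounds shown here, it shows that the free fraction at this place can move beyond the scatter, though modestly, on an exchange of chloro for methyl that leaves the counts of heavy atoms, rings, hydrogen-bond donors, hydrogen-bond acceptors and net charge unchanged, whereas the only earlier step, a 3.5-fold lower number from compound 2 to compound 3 (0.55 log units; beyond the scatter), concerned a methanesulfonamido group entering at another place on the shared core. Nothing at hand accounts for the shift from chloro to methyl.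

On these data alone, whether a fluoro, methoxy or nitrile group at this place would give a number nearer to compound 1 or to compound 4 stays open, and with it whether the read-out follows any order across such groups. Also open, as far as these compounds go, is whether the same exchange would give a step of similar size and direction on the butyl background of compound 2, since one pair on the carboxylic acid background of compound 1 cannot settle that.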